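The compounds below may be only part of what the source reports. "The series", "measured", "known", "first", "only" and "open" are said of these compounds alone.

Measured compounds:
compound 1 `COc1ccccc1CNc1ncnc2c1ncn2C1CCCCO1`; compound 2 `COc1cccc(OC)c1CNc1ncnc2c1ncn2C1CCCCO1`; compound 3 `COc1ccc(CNc2ncnc3c2ncn3C2CCCCO2)cc1OC`.

In an ADME assay on MCF7 cells (Homo sapiens) for cytotoxicity, with a stated time of 72 h (a higher number here means a weaker inhibitor, a lower number a stronger inhibitor), compound 1 gives > 100000 nM, which is a limit of the assay and not a number. In this assay compound 2 gives > 100000 nM, again a limit. In this assay compound 3 gives > 100000 nM, also a limit. The change from compound 1 to compound 2, (methoxy in place of hydrogen on an aromatic carbon), gives a step that the two limits leave unreadable from compound 1 to compound 2, because of the limit of > 100000 nM in this assay, at which 3 of the 3 values shown sit. How the core of compound 3 differs from that of compound 1 is not broken down here.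

Compound 4 `COc1cc(OC)c(OC)cc1CNc1ncnc2c1ncn2C1CCCCO1` is not yet measured. Its change from compound 3, (methoxy in place of hydrogen on an aromatic carbon), is the same kind of change as that from compound 1 to compound 2, though here the entering methoxy is also para to a methoxy group. Since compound 3 gives > 100000 nM and the earlier step is unreadable, compound 4 is expected to stay at the limit, the step of a number no higher from compound 3 to compound 4 (the limit leaves the size open) being estimated as near zero. Compound 4 is thus estimated at 100000 nM.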

Compound 4, half-maximal inhibitory concentration: > 100000 nM
Compound 4 ended at the assay's limit; the forecaster's own chance of this, stated with the estimate: 85%; the middle value lies on the limit itself.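

No step can be read from compound 3 to compound 4 in this assay, because both values are limits and not numbers: the limit of > 100000 nM in this assay, at which 4 of the 4 values shown sit.

The compounds shown leave open how far any of them lies from that limit, and whether methoxy in place of hydrogen changes the read-out at all.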